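Trimming the ether side chain down to a methoxy group

This account rests on a few compounds, and the source may have more. Where it says the series, first, only, none or still open, it means among the compounds named here.

Compound 3 `CCNC(=O)CCCOc1ccc(-c2nc3ncccn3c2NC2CCCCC2)cc1` sits at a limit of the assay in a toxicity assay on A549 cells (Homo sapiens) for cytotoxicity, read by luminescence and CellTiter-Glo, with a stated time of 48 h (a lower number here means that less compound is tolerated, a higher number that more compound is tolerated), where it gives > 100000 nM rather than a number. Compound 1 `CCCCOc1ccc(-c2nc3ncccn3c2NCc2ccccn2)cc1` in this assay likewise gives only a limit, > 100000 nM. Compound 2 `CCCCOc1ccc(-c2nc3ncccn3c2NCc2ccco2)cc1` in this assay gives 78000 nM. The only measured step among these three, an at least 1.2-fold lower number from compound 1 to compound 2 (0.10 log units; that floor lies within the scatter), is bounded by the limit of > 100000 nM in this assay, at which 2 of the 3 values shown sit, so the set offers no change in cytotoxicity that rises beyond the scatter.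

Compound 4 `COc1ccc(-c2nc3ncccn3c2NC2CCCCC2)cc1` differs from compound 3 by hydrogen in place of 2-(ethylcarbamoyl)ethyl on a saturated chain carbon bound to an oxygen on an aromatic ring. Among the measured compounds shown here, no measured step touches this side of the shared core; the one step that exists, an at least 1.2-fold lower number from compound 1 to compound 2 (0.10 log units; that floor lies within the scatter), concerns the other arm and stays within the scatter. Compound 4 is therefore expected to show no step beyond the scatter, and the change a number no higher from compound 3 to compound 4 (the limit leaves the size open) is the estimate. Compound 4 is expected to read about 100000 nM in this assay, within a range of 40000 nM to 250000 nM, most likely again only as a limit.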

Compound 4, half-maximal cytotoxic concentration: > 100000 nM
Compound 4: no number, only a limit; the forecaster's own chance of this, stated with the estimate: 70%; the middle value sits exactly at the limit.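

No step can be read from compound 3 to compound 4 in this assay, since both compounds give only a limit: the limit of > 100000 nM in this assay, at which 3 of the 4 values shown sit.

The compounds shown leave open whether exchanging 3-(ethylcarbamoyl)propoxy for methoxy changes the half-maximal cytotoxic concentration at all.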